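The source may report more compounds than this note shows. Statements on the series, on what has been measured and on what is new or still open speak of the compounds shown alone.

Compound 3 `COc1cc(N(C)CCN(C)C)c(NC(=O)c2ccncc2OC)cc1Nc1nccc(-c2cn(C)c3ccccc23)n1` gives 2690 nM in a functional assay on A549 cells (Homo sapiens) for antiproliferative activity, read by MTT assay, with a stated time of 72 h (on this read-out lower numbers stand for stronger inhibition and higher numbers for weaker inhibition), the lowest of the three numbers recorded. Compound 1 `COc1cc(F)c(NC(=O)c2ccncc2OC)cc1Nc1nccc(-c2cn(C)c3ccccc23)n1` gives 3430 nM, and a 1.3-fold lower number from compound 1 to compound 3 (0.11 log units; within the scatter) is within the scatter. Compound 2 `COc1cc(N(C)CCN(C)C)c(NC(=O)c2ccncc2)cc1Nc1nccc(-c2cn(C)c3ccccc23)n1` gives 10400 nM, so a 3.9-fold lower number from compound 2 to compound 3 (0.59 log units; beyond the scatter) is a modest step beyond the scatter. Compound 4 `COc1cc(N(C)CCN(C)C)c(NC(=O)c2ccncn2)cc1Nc1nccc(-c2cn(C)c3ccccc23)n1` differs from compound 3 by pyrimidin-4-yl in place of 3-methoxypyridin-4-yl on a carbonyl carbon. Within the data shown here, the step that bears on this is a 3.9-fold lower number from compound 2 to compound 3 (0.59 log units; beyond the scatter), in which the methoxy on the amide-bearing ring was added; compound 4 loses that methoxy and also exchanges the ring itself, for which no step exists. A modest weakening is therefore expected, near the size of a 3.9-fold lower number from compound 2 to compound 3 (0.59 log units; beyond the scatter). Compound 4 is estimated at 7000 nM, within 3000 nM to 18000 nM, which would mean an expected 2.6-fold higher number from compound 3 to compound 4 (0.42 log units; beyond the scatter).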

Compound 4, half-maximal inhibitory concentration: 2530 nM
The estimate for compound 4 lay 2.8-fold (0.44 log units) above the measured number; the whole stated range lies above it.
By their numbers in this assay, from the lowest: compounds 4, 3 and 1 (each within the scatter of the next); then compound 2.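

In this assay, pyrimidin-4-yl on the carbonyl carbon reads the same as 3-methoxypyridin-4-yl, with a 1.1-fold lower number from compound 3 to compound 4 (0.03 log units; within the scatter), so at this position the methoxy is not required once the ring holds two hetero atoms. Against pyridin-4-yl the new ring gives a 4.1-fold lower number from compound 2 to compound 4 (0.61 log units; beyond the scatter), so two different changes to that ring, this one and the added methoxy, each lower the number beyond the scatter. Nothing measured here accounts for this result. Still open, going by these compounds, is how a methoxy on the pyrimidin-4-yl ring, or a plain phenyl ring on the carbonyl carbon, would read.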